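The compounds below may be only part of what the source reports. "The series", "measured", "known", "first", "only" and "open" are said of these compounds alone.

Measured compounds in this series:

- compound 1, `O=C(O)c1cccc(-c2cnc(C(O)CCc3ccc(-c4ccccc4)cc3)o2)n1`: 1100 nM
- compound 2, `O=C(O)c1cccc(-c2cnc(CCCc3ccc(-c4ccccc4)cc3)o2)n1`: 10000 nM
- compound 3, `O=C(CCc1ccc(-c2ccccc2)cc1)c1ncc(-c2cccnc2)o1`: 1.1 nM

In an assay for inhibition of Fatty-acid amide hydrolase 1 (Rattus norvegicus) (a lower number here means a stronger inhibitor, a higher number a weaker inhibitor), compound 2 gives 10000 nM, the highest number of the three. Within the data shown here, its nearest neighbour is compound 1, which in this assay gives 1100 nM; the single measured step, a 9.1-fold higher number from compound 1 to compound 2 (0.96 log units; beyond the scatter), covers that gap. Among the measured compounds shown here, compound 3 gives 1.1 nM in this assay, far below both, but it differs from compound 2 in more than one place, so no single step connects them.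

The next compound, compound 4, `NC(=O)c1ccc(-c2cnc(CCCc3ccc(-c4ccccc4)cc3)o2)nc1`, differs from compound 2 in one place: 5-carbamoylpyridin-2-yl in place of 6-carboxypyridin-2-yl on an aromatic carbon. For the measured compounds named here, no measured step bears on this change; the one step on hand, a 9.1-fold higher number from compound 1 to compound 2 (0.96 log units; beyond the scatter), concerns a different position and is of no help here. The two acids, compound 1 and compound 2, both sit at weak numbers, while compound 3, which carries neither acid nor amide on its pyridyl ring, is the only strong one, but its carbonyl is a second difference. With nothing direct to lean on, the expected step of a 2.0-fold lower number from compound 2 to compound 4 (0.30 log units; within the scatter) is small and uncertain in direction. Compound 4 is therefore estimated at 5000 nM, within 1000 nM to 25000 nM.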

Compound 4, inhibition constant: 30000 nM
The estimate for compound 4 lay 6.0-fold (0.78 log units) below the measured number; the whole stated range lies below it.
By their numbers in this assay, from the lowest: compound 3; then compound 1; then compound 2; then compound 4.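

In this assay, the aromatic carbon next to the ring oxygen responds to a change of its pyridyl substituent: a 3.0-fold higher number from compound 2 to compound 4 (0.48 log units; beyond the scatter). Among these compounds, this is the first measured step at this position, as the earlier step concerned the saturated chain, and it runs towards weaker inhibition although the carboxylic acid of compound 2 was already at a weak number. The two groups match in heavy-atom count, hydrogen-bond donors, hydrogen-bond acceptors and net charge, so those counts do not account for the difference between 6-carboxypyridin-2-yl and 5-carbamoylpyridin-2-yl, and no measurement shown gives a reason for the step.

The step changes both the group and its place on the pyridine ring, as the two names show, so it cannot say which of these matters, and a nitrile or methyl ester in place of the carbamoyl group of 5-carbamoylpyridin-2-yl would test only part of that question. On these data alone, it also remains open whether the step would carry over to a core with the hydroxy-bearing chain of compound 1 or the carbonyl of compound 3.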